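The source may hold more compounds than are shown below. What is called first, only, known or untested is meant among the compounds shown, and "the series" means these compounds.

Measured so far in a functional assay on OVCAR-5 cells (Homo sapiens) for cytotoxicity, read by sulforhodamine B assay, with a stated time of 24 h; on this read-out lower numbers stand for stronger inhibition of growth and higher numbers for weaker inhibition of growth:
compound 1 `COc1ccc(C(=O)/C=C/c2cc3ccccc3[nH]c2=O)cc1`: 18400 nM
compound 2 `O=C(/C=C/c1cc2ccccc2[nH]c1=O)c1ccc(O)cc1`: 12800 nM

Compound 2 holds the lower of the two numbers seen so far in this assay, its nearest neighbour being compound 1. Among the compounds with values here, the only measured step, a 1.4-fold lower number from compound 1 to compound 2 (0.16 log units; within the scatter), lies within the scatter, so the two values cannot be placed in any order.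

Compound 3 `O=C(/C=C/c1cc2ccccc2[nH]c1=O)c1ccc(Cl)cc1` is the next member, not yet measured. Its difference from compound 2 is chloro in place of hydroxy on an aromatic carbon, a single-atom exchange on an aromatic carbon of a six-membered aromatic ring of carbon only, para to a large group. Within the data shown here, no measured step bears directly on this exchange. Among the measured compounds shown here, the one step available, a 1.4-fold lower number from compound 1 to compound 2 (0.16 log units; within the scatter), sits on the same ring but trades methyl for hydrogen on oxygen, and it stays within the scatter. There is thus no ground to expect a step beyond the scatter in either direction from compound 2 to compound 3. The expected value for compound 3 in this assay is 11000 nM, with a range from 4000 nM to 30000 nM. The step this estimate implies, a 1.2-fold lower number from compound 2 to compound 3 (0.07 log units; within the scatter), is expected to remain within the scatter.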

Compound 3, concentration for total growth inhibition: 97000 nM
Compound 3: middle estimate off by 8.8-fold (0.95 log units), on the low side, outside the stated range (above it).
By their numbers in this assay, from the lowest: compounds 2 and 1 (each within the scatter of the next); then compound 3.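

In this assay, within the data shown here, the aromatic carbon para to a large group turns out to be sensitive to what it carries: chloro in place of hydroxy gives a 7.6-fold higher number from compound 2 to compound 3 (0.88 log units; beyond the scatter), the first step beyond the scatter. Chloro in place of methoxy points the same way, with a 5.3-fold higher number from compound 1 to compound 3 (0.72 log units; beyond the scatter), while hydroxy and methoxy cannot be told apart, as a 1.4-fold lower number from compound 1 to compound 2 (0.16 log units; within the scatter) shows, so at this carbon the two oxygen-bearing groups stand together and chloro stands apart on the side of weaker inhibition of growth. Nothing available gives a reason for this separation.

The compounds shown leave open whether the separation follows the oxygen-bearing groups in general or is particular to chloro, a question that an amine, a fluoro group or a carboxylic acid on this same carbon would help to settle. Also open, going by these compounds, is whether the same separation holds with these groups on another carbon of the ring, or in cells other than those of this single assay.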